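The compounds below may be only part of what the source reports. "The series", "measured", "known", "first", "only" and "open" are said of these compounds alone.

Measured so far:
Compound 1 `O=C(Nc1ccc(Oc2ccnc3[nH]ccc23)cc1)c1cc(-c2ccccc2)ncn1` — 240 nM
Compound 2 `COc1ccc(-c2ccnc(C(=O)Nc3ccc(Oc4ccnc5[nH]ccc45)c(F)c3)n2)cc1` — 14100 nM
Compound 3 `O=C(Nc1ccc(Oc2ccnc3[nH]ccc23)c(F)c1)c1cc(-c2ccccc2)ncn1` — 40 nM

In a functional assay on PC-3 cells (Homo sapiens) for cytotoxicity, read by MTT assay, with a stated time of 72 h (a higher number here means a weaker inhibitor, a lower number a stronger inhibitor), compound 3 gives the lowest of the three numbers, with compound 1 nearest and compound 2 furthest away. Among the compounds with values here, the only step between compounds that differ in a single place is the one from compound 1 to compound 3, a 6.0-fold lower number from compound 1 to compound 3 (0.78 log units; beyond the scatter), which adds a fluorine to the ring bearing the amide nitrogen. Compound 2 differs from compound 3 in more than one place, so its much higher number cannot be tied to any single change.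

Compound 4 `O=C(Nc1ccc(Oc2ccnc3[nH]ccc23)c(F)c1)c1cc(-c2ccc(C(F)(F)F)cc2)ncn1` is not yet measured. It keeps everything in compound 3 and makes one change: trifluoromethyl in place of hydrogen on an aromatic carbon. Within the data shown here, no measured step touches this phenyl ring, so the fluorine step from compound 1 to compound 3 gives no direct guide; it shows only that a small change on an aromatic carbon can move the number beyond the scatter. With nothing closer to lean on, compound 4 is expected to land near compound 3, with a change of a 2.0-fold higher number from compound 3 to compound 4 (0.30 log units; within the scatter) in this assay that may not rise beyond the scatter. Compound 4 is therefore estimated at 80 nM, in a range from 20 nM to 400 nM.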

Compound 4, half-maximal inhibitory concentration: 4120 nM
Compound 4: middle estimate off by 52-fold (1.71 log units), on the low side; the whole stated range lies below it.
By their numbers in this assay, from the lowest: compound 3; then compound 1; then compound 4; then compound 2.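

Within the data shown here, compound 3 has a bare phenyl ring, and this is the first measured change on that ring. Going from phenyl to 4-(trifluoromethyl)phenyl, with the new group para to a large group, gives a 100-fold higher number from compound 3 to compound 4 (2.01 log units; beyond the scatter) in this assay, so this position is far from indifferent to what sits on it, and here a single added group makes compound 4 a much weaker inhibitor. Among these compounds, the only earlier single change, a 6.0-fold lower number from compound 1 to compound 3 (0.78 log units; beyond the scatter), lay on the ring bearing the amide nitrogen, moved the number the other way and was smaller in size, so the two places respond very differently to a fluorine-containing change. Nothing measured here explains why the number rises.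

Among the compounds shown here, with only one group compared against hydrogen at this position, it remains open whether the loss belongs to trifluoromethyl in particular or would follow from almost any group there, such as a single fluorine, a chlorine, an amine or a carboxylic acid. Compound 2 cannot settle this, as it differs from compound 3 in more than one place.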